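Series notes: bicyclic exchange on the ether of compound 1

The source may hold more compounds than are shown below. What is called first, only, known or untested is meant among the compounds shown, and "the series" means these compounds.

Compound 1 `CN(C)c1ccc(C(=O)Nc2cccc(NC(=O)COc3ccc4c(c3)CCC(=O)N4)c2)cc1` is the reference point of the present set. In an assay on isolated protein for inhibition of Rho-associated protein kinase 2 (Homo sapiens), read by scintillation counting, radiometric assay and 33P incorporation, with a stated time of 40 min, in the presence of a further agent that is not named here (on this read-out lower numbers stand for stronger inhibition and higher numbers for weaker inhibition), compound 1 gives 9970 nM, the highest of the three numbers on hand. Compound 2 `COc1cccc(OCC(=O)Nc2cccc(NC(=O)c3ccc(N(C)C)cc3)c2)c1` gives 5740 nM, and compound 3 `COc1cc(OCC(=O)Nc2cccc(NC(=O)c3ccc(N(C)C)cc3)c2)ccc1C=O` gives 306 nM. The step of a 1.7-fold lower number from compound 1 to compound 2 (0.24 log units; within the scatter) stays within the scatter, whereas a 33-fold lower number from compound 1 to compound 3 (1.51 log units; beyond the scatter) is large; the latter is matched by a 19-fold lower number from compound 2 to compound 3 (1.27 log units; beyond the scatter), which is formyl in place of hydrogen on an aromatic carbon.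

Compound 4 `CN(C)c1ccc(C(=O)Nc2cccc(NC(=O)COc3ccc4c(c3)OCCC4=O)c2)cc1` has not yet been measured. It differs from compound 1 by a group of 11 heavy atoms (9 carbon, 2 oxygen; one six-membered non-aromatic ring with 1 hetero atom, one six-membered aromatic ring of carbon only) in place of a group of 11 heavy atoms (9 carbon, 1 nitrogen, 1 oxygen; one six-membered non-aromatic ring with 1 hetero atom, one six-membered aromatic ring of carbon only), on an oxygen on a saturated carbon. The entering group keeps the non-aromatic ring and the aromatic ring but has no hydrogen-bond donor and two hydrogen-bond acceptors where the leaving group has one donor and one acceptor.

Among the measured compounds shown here, none of the measured steps makes this exchange directly: the step from compound 1 to compound 2 and the step from compound 1 to compound 3 both replace the bicyclic group with a single-ring group, and the large drop among them is carried by the formyl, which compound 4 lacks. The change in compound 4 is therefore expected to give no step beyond the scatter, with a lean toward a higher number, a 1.5-fold higher number from compound 1 to compound 4 (0.18 log units; within the scatter). Compound 4 is estimated at 15000 nM, within 5000 nM to 45000 nM.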

Compound 4, half-maximal inhibitory concentration: 85 nM
Beside the measured number, compound 4's estimate is 180-fold (2.25 log units) above it; the measured number lies below the stated range.
By their numbers in this assay, from the lowest: compound 4; then compound 3; then compounds 2 and 1 (each within the scatter of the next).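

This position responds strongly to the exchange even when the size and ring types stay the same: both groups have 11 heavy atoms and the same two rings, yet the move from one hydrogen-bond donor and one acceptor to no donor and two acceptors gives a 120-fold lower number from compound 1 to compound 4 (2.07 log units; beyond the scatter). The earlier compounds shown here showed a large step here only with the formyl, but compound 4 lacks that group and still stands apart from both single-ring compounds, with a 68-fold lower number from compound 2 to compound 4 (1.83 log units; beyond the scatter) and, more modestly, a 3.6-fold lower number from compound 3 to compound 4 (0.56 log units; beyond the scatter), so a formyl is not required for a low number on this oxygen-linked chain. Nothing available explains why the two bicyclic groups read so differently.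

From the compounds shown here alone, it remains open which feature of the entering group goes with the step, as the two groups differ in donor count, acceptor count and heavy-atom make-up all at once. Also open, going by these compounds, is how a hydroxyl in place of the carbonyl of the entering group, or an amine on its non-aromatic ring, would compare with compound 4.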